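Aryl change on the carbonyl: compound 2 to compound 3

The source may report more compounds than this note shows. Statements on the series, on what has been measured and on what is new or still open speak of the compounds shown alone.

Measured so far:
compound 1 `O=C1c2ccccc2C(=O)N1CCOC(=S)N(C(=O)c1ccc([N+](=O)[O-])cc1)c1ccc(Cl)cc1`: > 100000 nM (a limit)
compound 2 `O=C1c2ccccc2C(=O)N1CCOC(=S)N(C(=O)c1cc(F)cc(F)c1)c1ccc(Cl)cc1`: 59000 nM

Within the data shown here, in an ADME assay on MT4 cells (Homo sapiens) for cytotoxicity, read by MTT assay (a lower number here means that less compound is tolerated, a higher number that more compound is tolerated), compound 2 gives 59000 nM, the only actual number so far. Compound 1 gives > 100000 nM, which is a limit of the assay and not a number.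

Compound 3 `O=C1c2ccccc2C(=O)N1CCOC(=S)N(C(=O)c1c(Cl)cccc1Cl)c1ccc(Cl)cc1` carries 2,6-dichlorophenyl in place of 3,5-difluorophenyl on a carbonyl carbon. The core and the other groups stay the same.

Among the measured compounds shown here, the one measured step at this place is an at least 1.6-fold lower number from compound 1 to compound 2 (0.22 log units; that floor lies within the scatter). It is bounded from one side only, and its floor lies within the scatter. It involves a different pair of groups, so it gives only weak guidance. No step beyond the scatter is therefore expected in this assay, in either direction, although a reading at the limit of the assay remains possible for compound 3.

The estimated step is a 1.1-fold lower number from compound 2 to compound 3 (0.03 log units; within the scatter). For compound 3 the expected value is 55000 nM, with an estimated range of 22000 nM to 100000 nM.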

Compound 3, half-maximal cytotoxic concentration: 20000 nM
Compound 3: middle estimate off by 2.8-fold (0.44 log units), on the high side; measured number below the stated range.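

In this assay, among these compounds, the group on the carbonyl carbon now gives a step that clears the scatter, which the earlier compounds could not show: a 3.0-fold lower number from compound 2 to compound 3 (0.47 log units; beyond the scatter). Against the 4-nitrophenyl compound the result is also clear, with an at least 5.0-fold lower number from compound 1 to compound 3 (0.69 log units; beyond the scatter), whereas the earlier step at this place had a floor within the scatter, so this position is not neutral for the tolerated concentration in the series. The second step is only a floor, as compound 1 reads as a limit of the assay and not as a number: the limit of > 100000 nM in this assay, at which 1 of the 3 values shown sits.

The step from compound 2 to compound 3, 2,6-dichlorophenyl in place of 3,5-difluorophenyl, changes two things at once, fluorine to chlorine and the substitution pattern, so the compounds shown cannot say which of the two goes with the lower number. A 3,5-dichlorophenyl or a 2,6-difluorophenyl on the same carbonyl carbon would separate the two, and an unsubstituted phenyl would give a reference for all three aryl groups.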